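The source may hold more compounds than are shown below. What is called first, only, known or untested is meant among the compounds shown, and "the series" means these compounds.

Values in an ADME assay on HepG2 cells (Homo sapiens) for cytotoxicity, with a stated time of 72 h; on this read-out higher numbers stand for an effect only at larger amounts of compound and lower numbers for an effect already at smaller amounts:
- compound 1 `Cc1cc(NC(=O)Nc2ccc(C(N)=O)cc2)c2ccccc2n1`: > 25000 nM (a limit)
- compound 2 `Cc1cc(NC(=O)Nc2ccc(OC(F)(F)F)cc2)c2ccccc2n1`: 15000 nM
- compound 3 `Cc1cc(NC(=O)Nc2ccc(C(=O)O)cc2)c2ccccc2n1`: > 25000 nM (a limit)

Compound 3 gives > 25000 nM, which is a limit and not a number. For the measured compounds named here, the series so far shows (the limit of > 25000 nM in this assay, at which 2 of the 3 values shown sit).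

Compound 4 `Cc1cc(NC(=O)Nc2ccc(C(=O)O)c(O)c2)c2ccccc2n1` differs by hydroxy in place of hydrogen on an aromatic carbon, ortho to a carboxy group.

The nearest evidence is an at least 1.6-fold lower number from compound 1 to compound 2 (0.22 log units; that floor lies within the scatter) and an at least 1.6-fold higher number from compound 2 to compound 3 (0.22 log units; that floor lies within the scatter). Both swap a different group, and neither measures a hydroxy. The third pair gives only a step that the two limits leave unreadable from compound 1 to compound 3.

No change beyond the scatter is therefore expected in this assay, and the expected step is a number no higher from compound 3 to compound 4 (the limit leaves the size open). A further limit is likely.

For compound 4 the estimated value is 25000 nM, with an expected range of 12000 nM to 50000 nM.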

Compound 4, half-maximal effective concentration: > 25000 nM
Compound 4: no number, only a limit (the forecaster's own chance of this, stated with the estimate: 75%); the middle value sits exactly at the limit.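

No step from compound 3 to compound 4 can be read in this assay, since both values are limits: the limit of > 25000 nM in this assay, at which 3 of the 4 values shown sit.

From the compounds shown here alone, whether hydroxy in place of hydrogen, ortho to a carboxy group, changes this read-out at all remains open.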